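Swapping the Benzothiophene for a Bromophenyl Group

The source may hold more compounds than are shown below. What is called first, only, known or untested is meant among the compounds shown, and "the series" means these compounds.

Of the compounds shown here, three built on one shared core have been tested in an ADME assay on GES1 cells (Homo sapiens) for inhibition, read by MTT assay, with a stated time of 72 h; a lower number here means a stronger inhibitor, a higher number a weaker inhibitor. Compound 1 `Cc1ccc(CSc2nc3nc(C)cc(Nc4cc(-c5ccccc5)[nH]n4)n3n2)cc1` gives 36200 nM, compound 2 `Cc1cc(Nc2cc(-c3ccccc3)[nH]n2)n2nc(SCc3c(Cl)cccc3Cl)nc2n1` gives 39600 nM, and compound 3 `Cc1cc(Nc2cc(-c3ccccc3)[nH]n2)n2nc(SCc3csc4ccccc34)nc2n1` gives 29200 nM. Compound 3 stands at the low end of these three numbers, but its separations from the others are small: a 1.2-fold lower number from compound 1 to compound 3 (0.09 log units; within the scatter) and a 1.4-fold lower number from compound 2 to compound 3 (0.13 log units; within the scatter), so no ranking among the three can be read from them. The remaining step, a 1.1-fold higher number from compound 1 to compound 2 (0.04 log units; within the scatter), likewise stayed within the scatter. Compound 4 `Cc1cc(Nc2cc(-c3ccccc3)[nH]n2)n2nc(SCc3cccc(Br)c3)nc2n1` is the next variation, in which (3-bromophenyl in place of 1-benzothiophen-3-yl on a saturated chain carbon bound to a sulfur). Among the compounds with values here, every measured step so far changed only the group on the saturated chain carbon bound to a sulfur, and none of them moved the number beyond the scatter, so a further change at that place is expected to give no step beyond the scatter in this assay. The expected step is a 1.1-fold higher number from compound 3 to compound 4 (0.05 log units; within the scatter). Compound 4 is therefore estimated at 33000 nM, with a range from 18000 nM to 60000 nM.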

Compound 4, half-maximal inhibitory concentration: > 50000 nM
Compound 4: no number, only a limit; the forecaster's own chance of this, stated with the estimate: 10%; middle value at least 1.5-fold (0.18 log units) from the limit.
By their numbers in this assay, from the lowest: compounds 3, 1 and 2 (each within the scatter of the next). At a limit, above all of these: compound 4.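

In this assay compound 4 is the only one of the series whose reading is a limit and not a number: the limit of > 50000 nM in this assay, at which 1 of the 4 values shown sits. The steps to it are therefore floors only, with an at least 1.7-fold higher number from compound 3 to compound 4 (0.23 log units; that floor lies within the scatter) and an at least 1.2-fold higher number from compound 2 to compound 4 (0.10 log units; that floor lies within the scatter) and also an at least 1.3-fold higher number from compound 1 to compound 4 (0.14 log units; that floor lies within the scatter) in the same position. At this place, on a saturated chain carbon bound to a sulfur, the change to 3-bromophenyl is thus the first that may lie beyond the scatter, yet no floor shows that it does.

As far as these compounds go, how far compound 4 truly stands from the other three remains unknown. The groups shown at this place are all aromatic, so how an amine or a carboxylic acid there would read also stays open.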